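Aryl Ketone Variation on a Shared Core

The source may hold more compounds than are shown below. What is called first, only, known or untested is meant among the compounds shown, and "the series" means these compounds.

Compound 1 `COc1cc(-c2nnc3n2NC(c2ccco2)C(C(=O)c2ccc(Br)cc2)S3)cc(OC)c1OC`: 42100 nM
Compound 2 `COc1cc(-c2nnc3n2NC(c2ccco2)C(C(=O)c2ccc(F)c(F)c2)S3)cc(OC)c1OC`: 93700 nM

Among the compounds with values here, compound 2 holds the higher of the two numbers in a functional assay on A549 cells (Homo sapiens) for cytotoxicity, read by MTT assay, with a stated time of 48 h (a higher number here means a weaker inhibitor, a lower number a stronger inhibitor), its only neighbour being compound 1. Compound 3 `COc1cc(-c2nnc3n2NC(c2ccco2)C(C(=O)c2ccc(-c4ccccc4)cc2)S3)cc(OC)c1OC` differs from compound 2 by 4-phenylphenyl in place of 3,4-difluorophenyl on a carbonyl carbon. Within the data shown here, the one measured step at this carbonyl position, a 2.2-fold higher number from compound 1 to compound 2 (0.35 log units; beyond the scatter), was modest, so a swap of the aryl group on that carbon has so far shifted this assay only a little, and no measured step covers a 4-phenylphenyl group. Compound 3 is therefore expected to give about 45000 nM in this assay , within 12000 nM to 160000 nM. The expected step is a 2.1-fold lower number from compound 2 to compound 3 (0.32 log units; beyond the scatter).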

Compound 3, half-maximal inhibitory concentration: > 100000 nM
Compound 3 ended at the assay's limit (the forecaster's own chance of this, stated with the estimate: 15%); middle value at least 2.2-fold (0.34 log units) from the limit.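

In this assay compound 3 sits at a limit of the assay, not at a number: the limit of > 100000 nM in this assay, at which 1 of the 3 values shown sits. Phenyl in place of bromo on an aromatic carbon gives an at least 2.3-fold higher number from compound 1 to compound 3 (0.37 log units; beyond the scatter), so at this position an added ring moves the result away from the stronger end of the series. Against the 3,4-difluorophenyl group only a floor can be read, an at least 1.0-fold higher number from compound 2 to compound 3 (0.02 log units; that floor lies within the scatter), and it sets no order between those two compounds. On these data alone, whether an amine or a carboxylic acid in place of bromo on that aromatic carbon would give a lower number than compound 1 stays open.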